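Styrylsulfonamides on K562 Cells: Three Measured, One Awaited

The compounds below may be only part of what the source reports. "The series", "measured", "known", "first", "only" and "open" are said of these compounds alone.

Measured compounds:
compound 1, `O=S(=O)(/C=C/c1ccccc1)Nc1ccc(Cl)cc1`, gives 20000 nM in a functional assay on K562 cells (Homo sapiens) for cytotoxicity, read by trypan blue exclusion, with a stated time of 96 h; on this read-out higher numbers stand for weaker inhibition and lower numbers for stronger inhibition
compound 2, `COc1cc(OC)c(/C=C/S(=O)(=O)Nc2ccc(OC)c(OC(=O)C(C)(C)C3=C(C)C(=O)C=C(C)C3=O)c2)c(OC)c1`, gives 8 nM
compound 3, `COC(=O)C(C)Nc1cc(NS(=O)(=O)/C=C/c2c(OC)cc(OC)cc2OC)ccc1OC`, gives 300 nM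

Of the three numbers in this assay, compound 3 holds the second highest. Compound 2 lies nearest with a lower number, compound 1 furthest with a higher one, and both gaps lie beyond the scatter. Compound 4, `COc1cc(OC)c(/C=C/S(=O)(=O)Nc2ccc(OC)c(NC(C(=O)O)c3ccc(F)cc3)c2)c(OC)c1`, is not yet measured in this assay. It differs from compound 3 in one place: carboxy(4-fluorophenyl)methyl in place of 1-(methoxycarbonyl)ethyl on a nitrogen on an aromatic ring. Going by the values given here, no measured pair shares this change, so the step cannot be read from a precedent; the larger group than that of compound 3 is carried by compound 2, which gives 8 nM, but that is thin ground. The step from compound 3 to compound 4 is expected to be small, a 1.5-fold lower number from compound 3 to compound 4 (0.18 log units; within the scatter), toward a lower number. Compound 4 is therefore estimated at 200 nM, within 40 nM to 1000 nM.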

Compound 4, half-maximal inhibitory concentration: 20 nM
The estimate for compound 4 lay 10-fold (1.00 log units) above the measured number, and the stated range ends above it.
By their numbers in this assay, from the lowest: compound 2; then compound 4; then compound 3; then compound 1.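

Read in this assay the swap of 1-(methoxycarbonyl)ethyl for carboxy(4-fluorophenyl)methyl gives a 15-fold lower number from compound 3 to compound 4 (1.18 log units; beyond the scatter) and so shows that a larger group on this nitrogen on an aromatic ring can go with a lower number. Going by these compounds alone, it also gives the first step that can be read in one place, and it shows that the number responds to the group on this nitrogen. Nothing available bears on the reason for this step. The methoxycarbonyl, the carboxy and the 4-fluorophenyl differ together here, so their shares stay apart from view. A plain phenyl or an amide on the same carbon would leave that question open as well.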